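The source may hold more compounds than are shown below. What is called first, only, known or untested is meant among the compounds shown, and "the series" means these compounds.

Compound 1, `COC(=O)C(C)(C)NC(=O)c1cc(F)cc2cc(-c3ccc(Cl)cc3)oc12`, gives > 10000 nM in an assay on isolated protein for inhibition of endoplasmic reticulum aminopeptidase 1 (Homo sapiens), with stated times of 15 min and 20 min; on this read-out lower numbers stand for stronger inhibition and higher numbers for weaker inhibition; this is a limit of the assay, not a number.
Compound 2, `O=C(NC1(C(=O)O)CC1)c1cc(F)cc2cc(-c3ccc(Cl)cc3)oc12`, gives 1120 nM in this assay.

Compound 2 holds the only number shown in this assay, the other value being a limit (the limit of > 10000 nM in this assay, at which 1 of the 2 values shown sits). Compound 3, `O=C(NC1(C(=O)O)CCCCC1)c1cc(F)cc2cc(-c3ccc(Cl)cc3)oc12`, is not yet measured. It differs from compound 2 in one place: 1-carboxycyclohexyl in place of 1-carboxycyclopropyl on an amide-type nitrogen. Among the compounds with values here, the only measured step, an at least 8.9-fold lower number from compound 1 to compound 2 (0.95 log units; beyond the scatter), changed both the ester and the ring at that nitrogen at once, so it bears on this step only partly: it shows that the substituent on the amide-type nitrogen matters, but it does not separate the ring size from the acid. The step from compound 2 to compound 3 keeps the acid and enlarges the ring only. Within the data shown here, with no measured step that isolates ring size, the expectation is a change within the scatter or a modest weakening, and compound 3 is estimated at 1800 nM (range 350 nM to 9000 nM), which means an expected step of a 1.6-fold higher number from compound 2 to compound 3 (0.21 log units; within the scatter).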

Compound 3, half-maximal inhibitory concentration: 34 nM
Estimate against measurement, compound 3: 53-fold (1.72 log units) above; the measured number lies below the stated range.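

With the carboxylic acid kept in place, enlarging the ring alone, from 1-carboxycyclopropyl to 1-carboxycyclohexyl on the amide-type nitrogen, gives a 33-fold lower number from compound 2 to compound 3 (1.52 log units; beyond the scatter) in this assay, so ring size at this position matters strongly on its own, which the earlier step, with ester and ring changed together, could not show. The whole change from 1-(methoxycarbonyl)-1-methylethyl to 1-carboxycyclohexyl amounts to an at least 290-fold lower number from compound 1 to compound 3 (2.46 log units; beyond the scatter), and this step has no fixed size since its starting point is a limit of the assay, not a number: the limit of > 10000 nM in this assay, at which 1 of the 3 values shown sits. Nothing shown accounts for why the six-membered ring gives the lower number.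

With only the three-membered and six-membered rings shown, it remains open whether the number falls steadily with ring size or whether a 1-carboxycyclobutyl, 1-carboxycyclopentyl or 1-carboxycycloheptyl group would do as well or better. Within the data shown here, also open is how much the carboxylic acid itself contributes, a question that the methyl ester or the primary amide on the same cyclohexyl ring would address, since no pair here changes the acid alone.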